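Swapping the Sulfur Substituent in a Weak Growth Inhibitor

The compounds below may be only part of what the source reports. "The series", "measured", "known", "first", "only" and "open" are said of these compounds alone.

Measured compounds:
- compound 1 `COc1ccccc1/C=C(/SCc1ccc(Cl)cc1)C(=O)c1ccc(Cl)cc1`: 1000 nM
- compound 2 `Cc1ccc(/C=C(/SCc2ccc(Cl)cc2)C(=O)c2ccc(Cl)cc2)s1`: 50000 nM

Both compounds were tested in a functional assay on DU-145 cells (Homo sapiens) for inhibition, read by trypan blue exclusion, with a stated time of 96 h; a lower number here means a stronger inhibitor of growth, a higher number a weaker inhibitor of growth. Among the compounds with values here, compound 2 has the highest number of the two; its nearest neighbour is compound 1, and the only measured step, a 50-fold higher number from compound 1 to compound 2 (1.70 log units; beyond the scatter), is large and beyond the scatter. Compound 3 `Cc1ccc(/C=C(/Sc2ccc(F)cc2)C(=O)c2ccc(Cl)cc2)s1` differs from compound 2 only at the sulfur: 4-fluorophenyl in place of 4-chlorobenzyl on a sulfur. Within the data shown here, no measured step touches this part of the molecule; the one known step changes the aryl group on the chain carbon instead, so it gives no guidance for what a change at the sulfur does. With nothing to lean on, the expectation is that compound 3 lands near compound 2, with no step beyond the scatter, and a wide range to allow for the unknown: no change at the digits printed from compound 2 to compound 3 (within the scatter). The estimate for compound 3 is 50000 nM, between 12000 nM and 200000 nM.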

Compound 3, concentration for 50% growth inhibition: 25000 nM
The estimate for compound 3 lay 2.0-fold (0.30 log units) above the measured number, within the range that was stated.
By their numbers in this assay, from the lowest: compound 1; then compounds 3 and 2 (each within the scatter of the next).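

Moving from 4-chlorobenzyl to 4-fluorophenyl on the sulfur gives a 2.0-fold lower number from compound 2 to compound 3 (0.30 log units; within the scatter) in this assay and so shows that, with this 5-methylthiophen-2-yl compound, the two sulfur groups cannot be told apart in this test. Within the data shown here, the change at the sulfur therefore stands in contrast to the aryl swap on the chain carbon, which gave a 50-fold higher number from compound 1 to compound 2 (1.70 log units; beyond the scatter) and remains the only step here beyond the scatter. Nothing available explains why these two sulfur groups read alike. From the compounds shown here alone, it remains open whether the same swap on the sulfur would also make so little difference in compound 1, where the 2-methoxyphenyl group is present. Going by these compounds, it is also open how this assay would respond to very different sulfur groups, such as a 2-phenylethyl chain or a phenyl ring carrying an amine or a carboxylic acid.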